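The source may report more compounds than this note shows. Statements on the series, on what has been measured and on what is new or still open speak of the compounds shown alone.

Three compounds sharing one core have been measured in a functional assay on cells (Cancer cell lines, Homo sapiens) for inhibition, with a stated time of 48 h; a lower number here means a stronger inhibitor of growth, a higher number a weaker inhibitor of growth:

compound 1, `NNC(=O)c1c(NC(=O)NS(=O)(=O)c2ccccc2)sc2c1CCCCC2` — for compound 1 the result is > 100000 nM, which is a limit of the assay and not a number.
compound 2, `O=C(Nc1sc2c(c1C(=O)NNc1ccccc1)CCCCC2)NS(=O)(=O)c1ccccc1` — compound 2 gives 26300 nM.
compound 3, `CN1CCN(C(=O)c2c(NC(=O)NS(=O)(=O)c3ccccc3)sc3c2CCCCC3)CC1` — compound 3 gives 42300 nM.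

Of the two numbers shown, compound 3 holds the higher one, but its gap to compound 2, a 1.6-fold higher number from compound 2 to compound 3 (0.21 log units; within the scatter), stays within the usual scatter, so the two cannot be told apart. Compound 1 reached only (the limit of > 100000 nM in this assay, at which 1 of the 3 values shown sits); the steps of an at least 3.8-fold lower number from compound 1 to compound 2 (0.58 log units; beyond the scatter) and an at least 2.3-fold lower number from compound 1 to compound 3 (0.37 log units; beyond the scatter) show that either replacement on the carbonyl carbon brings the number down from that limit.

Compound 4, `O=C(Nc1sc2c(c1C(=O)NNc1ccc(Br)cc1)CCCCC2)NS(=O)(=O)c1ccccc1`, has not been measured. It differs from compound 3 by ((4-bromophenyl)amino)amino in place of 4-methylpiperazin-1-yl on a carbonyl carbon. This largely undoes the change that separates compound 2 from compound 3, except that the entering group carries a bromine, which the anilinoamino of compound 2 lacks. For the measured compounds named here, since the step of a 1.6-fold higher number from compound 2 to compound 3 (0.21 log units; within the scatter) was within the scatter, the return to a hydrazide bearing an aromatic ring is expected to bring at most a modest gain; the bromine has no measured counterpart among the three compounds. Accordingly the expected step is a 2.8-fold lower number from compound 3 to compound 4 (0.45 log units; beyond the scatter). Compound 4 is estimated at 15000 nM, with a range from 4000 nM to 60000 nM.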

Compound 4, concentration for 50% growth inhibition: 11500 nM
Estimate against measurement, compound 4: 1.3-fold (0.12 log units) above, within the range that was stated.
By their numbers in this assay, from the lowest: compound 4; then compounds 2 and 3 (each within the scatter of the next). At a limit, above all of these: compound 1.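

In this assay, bromo in place of hydrogen on an aromatic carbon gives a 2.3-fold lower number from compound 2 to compound 4 (0.36 log units; beyond the scatter), so a small change on the ring of the hydrazide can move the number by more than the scatter. The earlier compounds shown here could not separate anilinoamino from 4-methylpiperazin-1-yl on the carbonyl carbon, but ((4-bromophenyl)amino)amino in place of 4-methylpiperazin-1-yl gives a 3.7-fold lower number from compound 3 to compound 4 (0.57 log units; beyond the scatter), which is a difference that can be read. Compound 1 remains a limit and not a number, so with 4-bromophenyl in place of hydrogen on an amine nitrogen, an at least 8.6-fold lower number from compound 1 to compound 4 (0.93 log units; beyond the scatter) gives only a minimum size for this change: the limit of > 100000 nM in this assay, at which 1 of the 4 values shown sits.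

As far as these compounds go, whether this gain is special to bromine remains open, and a chloro, methoxy or nitro group in the place of the bromo would help to settle that. Also open, from the compounds shown here alone, is how much the rest of the molecule matters, as the other parts of the shared core stay the same in all four compounds.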